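From Furan-3-yl to Furan-2-yl: What Compound 4 Should Show

The compounds below may be only part of what the source reports. "The series", "measured", "known", "first", "only" and "open" are said of these compounds alone.

Of the compounds shown here, three of a shared core have been measured in a functional assay on DU-145 cells (Homo sapiens) for cytotoxicity, in the presence of a further agent that is not named here; on this read-out lower numbers stand for stronger inhibition and higher numbers for weaker inhibition. Compound 1 `Clc1ccc(-c2cc(-c3ccoc3)cc(-c3cccs3)n2)cc1` gives 21100 nM in this assay. Compound 2 `Clc1ccc(-c2cc(-c3ccoc3)cc(-c3ccsc3)n2)cc1` gives 37600 nM, and compound 3 `Cc1ccc(-c2cc(-c3ccc(Cl)o3)cc(-c3cccs3)n2)cc1` gives 19300 nM. Compound 1 thus stands in the middle of the three numbers; its nearest neighbour is compound 3 and its furthest is compound 2, and both of these gaps lie within the scatter of repeated measurements.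

Among the measured compounds shown here, only one single-point step is available among the measured compounds: a 1.8-fold higher number from compound 1 to compound 2 (0.25 log units; within the scatter), a change of one five-membered ring from thiophen-2-yl to thiophen-3-yl that left the number within the scatter.

Compound 4 `Clc1ccc(-c2cc(-c3ccco3)cc(-c3cccs3)n2)cc1` is not yet measured. It differs from compound 1 in one place: furan-2-yl in place of furan-3-yl on an aromatic carbon. This is the same kind of change as the measured step, a five-membered ring with one hetero atom re-joined through a different ring carbon, though on the furan rather than the thiophene. Since that step from compound 1 to compound 2 stayed within the scatter, no step beyond the scatter is expected here either, in this assay. Compound 4 is therefore estimated to give 22000 nM in this assay, with a range of 9000 nM to 55000 nM, meaning an expected step of a 1.0-fold higher number from compound 1 to compound 4 (0.02 log units; within the scatter).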

Compound 4, half-maximal inhibitory concentration: > 100000 nM
Compound 4 gave a limit, no number; the forecaster's own chance of this, stated with the estimate: 10%; at least 4.5-fold (0.65 log units) between middle value and limit.
By their numbers in this assay, from the lowest: compounds 3, 1 and 2 (each within the scatter of the next). At a limit, above all of these: compound 4.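

The position opposite the ring nitrogen proves sensitive to how its five-membered ring is joined: with the same atoms and the same counts of hydrogen-bond donors and acceptors, furan-2-yl in place of furan-3-yl gives an at least 4.7-fold higher number from compound 1 to compound 4 (0.67 log units; beyond the scatter) in this assay. Among the compounds shown here, the one earlier change of this kind, thiophen-3-yl in place of thiophen-2-yl, gave a 1.8-fold higher number from compound 1 to compound 2 (0.25 log units; within the scatter), so re-joining a ring through a different carbon does not have the same outcome on the furan as on the thiophene in these two steps. Compound 4 is known here only as a limit, not as a number: the limit of > 100000 nM in this assay, at which 1 of the 4 values shown sits.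

The compounds shown leave open whether this sensitivity belongs to the furan alone or would also appear with a thiophen-2-yl or pyrrol-2-yl group opposite the ring nitrogen. They also leave open whether an amine or a carboxylic acid carried on the furan-2-yl ring of compound 4 would bring its number back to the level of compound 1.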